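This account rests on a few compounds, and the source may have more. Where it says the series, first, only, none or still open, it means among the compounds named here.

Measured compounds:
Compound 1, `COc1cccc(N2CCN(C(=O)C(C)N3C(=O)CCC3=O)CC2)c1`, giving 0%.
Compound 2, `COCC(C(=O)N1CCN(c2cccc(C(F)(F)F)c2)CC1)N1C(=O)CCC1=O`, giving 100%.

Going by the values given here, in a functional assay on the whole organism (strain Swiss) with Mus musculus as the target, in the maximal electroshock model, with a stated time of 1 h, at a dose of 300 mg/kg by the intraperitoneal route (a higher number here means a stronger effect of the compound at the dose given, a lower number a weaker effect), compound 1 gives 0%, which is the lowest of the two numbers known. Its nearest neighbour by number is compound 2, which in this assay gives 100%, a gap that lies beyond the usual scatter; the two compounds differ in more than one place, so their values are simply set side by side.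

The account now follows compound 1 to compound 3, `CC(C(=O)N1CCN(c2ccccc2)CC1)N1C(=O)CCC1=O`, which has not yet been measured in this assay. The change is hydrogen in place of methoxy on an aromatic carbon. Among the compounds with values here, no pair of measured compounds shows the effect of this change, so the expected step rests only on the position of compound 1 at the floor of the read-out. A move downward is not possible from there; the step from compound 1 to compound 3 is expected to be a number 20 percentage points higher from compound 1 to compound 3 (beyond the scatter), upward and modest, with no step beyond the scatter held to be the likeliest outcome.

For compound 3 in this assay the estimate is 20%, within a range from 0% to 70%.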

Compound 3, a percentage reported as activity, at one dose (the size of the read-out at that dose, not a potency): 50%
For compound 3 the middle estimate is 30 percentage points below the measured one; the range from low to high includes it.
By their numbers in this assay, from the lowest: compound 1; then compound 3; then compound 2.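

In this assay, replacing methoxy with hydrogen on the aromatic carbon meta to a large group gives a number 50 percentage points higher from compound 1 to compound 3 (beyond the scatter) and shows that this position is not indifferent. Going by these compounds alone, the earlier compounds differed in more than one place and could not show this, whereas here the single change from 3-methoxyphenyl to phenyl, with the rest of the core unchanged, is enough to lift the read-out from the floor where compound 1 stands. Nothing available bears on the reason for this step.

This single pair cannot tell whether the step reflects the loss of methoxy specifically or whether other groups at the same place, such as hydroxy, ethoxy or chlorine, would give values like that of compound 1 or that of compound 3. It also leaves open whether the same change would have a similar effect on a core carrying a different chain, such as the methoxymethyl group of compound 2, which differs from these two compounds in more than one place.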